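This account rests on a few compounds, and the source may have more. Where it says the series, first, only, none or still open, it means among the compounds named here.

Compound 1, `c1ccc(-c2cn3ccnc3c(-c3ccc4ncn(C5CCCCC5)c4c3)n2)cc1`: 48.3%
Compound 2, `CC(=O)c1ccc(-c2cn3ccnc3c(-c3ccc4ncn(C5CCCCC5)c4c3)n2)cc1`: 9.2%
Compound 3, `COc1ccccc1-c1cn2ccnc2c(-c2ccc3ncn(C4CCCCC4)c3c2)n1`: 11.1%

In a functional assay on HT-29 cells (Homo sapiens) for inhibition, read by sulforhodamine B assay, with a stated time of 48 h, tested at 10 uM (on this read-out lower numbers stand for less inhibition and higher numbers for more inhibition at the one concentration tested (going by the name of the read-out)), compound 3 stands second highest of the three, close to compound 2 but well below compound 1. Compound 4, `Fc1ccccc1-c1cn2ccnc2c(-c2ccc3ncn(C4CCCCC4)c3c2)n1`, differs from compound 3 by fluoro in place of methoxy on an aromatic carbon. For the measured compounds named here, no measured step exchanges methoxy for fluoro, so the bearing is indirect: methoxy in place of hydrogen gave a number 37.2 percentage points lower from compound 1 to compound 3 (beyond the scatter), acetyl in place of hydrogen gave a number 39.1 percentage points lower from compound 1 to compound 2 (beyond the scatter), and exchanging one substituted ring for the other gave a number 1.9 percentage points higher from compound 2 to compound 3 (within the scatter). Fluoro is the smaller group of the two, so a partial move back toward the unsubstituted compound 1 seems plausible, though not a full return. Compound 4 is therefore expected to give 25%, in the range 5% to 50%. This estimate means a step of a number 13.9 percentage points higher from compound 3 to compound 4 (beyond the scatter).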

Compound 4, a percentage reported as inhibition, at one concentration (the size of the read-out at that concentration, not a potency): 7.26%
For compound 4 the middle estimate is 17.7 percentage points above the measured one, and the stated range covers the measured number.
By their numbers in this assay, from the lowest: compounds 4, 2 and 3 (each within the scatter of the next); then compound 1.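

In this assay, fluoro in place of methoxy at this place, ortho to a large group, gives a number 3.8 percentage points lower from compound 3 to compound 4 (within the scatter) and so a single fluorine atom reads like the larger methoxy here. The comparison with the 4-acetylphenyl compound gives a number 1.9 percentage points lower from compound 2 to compound 4 (within the scatter) while fluoro in place of hydrogen gives a number 41 percentage points lower from compound 1 to compound 4 (beyond the scatter) and so all three substituted rings sit well under the unsubstituted ring of compound 1. Nothing available explains this loss. Still open, going by these compounds, is whether an amine or a hydroxyl at this place would stay equally low, and whether fluoro on another carbon of that ring would do the same.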